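This account rests on a few compounds, and the source may have more. Where it says the series, first, only, none or still open, it means among the compounds named here.

Two compounds that share a core have been run in an ADME assay on cells (Homo sapiens) for cytotoxicity, read by polymerase chain reaction, with a stated time of 3 days; a lower number here means that less compound is tolerated, a higher number that more compound is tolerated. Compound 1 `COc1ccc2nc(-c3c(Cl)nc(N)nc3N[C@@H]3C[C@H](CO)[C@@H](O)[C@H]3O)sc2c1` gives only a limit there, > 25000 nM. Going by the values given here, compound 2 `Cc1nc(NCCOC(C)C)nc(N[C@@H]2C[C@H](CO)[C@@H](O)[C@H]2O)c1-c1nc2ccccc2s1` gives 8000 nM, the only actual number measured so far. The other value shown, that of compound 1, is a limit, (the limit of > 25000 nM in this assay, at which 1 of the 2 values shown sits). Among the compounds with values here, no pair of measured compounds differing in just one place is available, so no measured step shows what a single change does to the tolerated concentration here.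

Compound 3 `Cc1nc(NCc2cccnc2)nc(N[C@@H]2C[C@H](CO)[C@@H](O)[C@H]2O)c1-c1nc2ccccc2s1` has not yet been measured. It differs from compound 2 in one place: pyridin-3-yl in place of isopropoxymethyl on a saturated chain carbon bound to a nitrogen on an aromatic ring. Within the data shown here, with no measured step to lean on, the step expected, no change at the digits printed from compound 2 to compound 3 (within the scatter), is none beyond the usual scatter. Compound 3 is therefore estimated at 8000 nM in this assay, with a likely range from 2500 nM to 25000 nM.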

Compound 3, half-maximal cytotoxic concentration: 5000 nM
Beside the measured number, compound 3's estimate is 1.6-fold (0.20 log units) above it, within the range that was stated.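

In this assay, this position now has its first measured step, a 1.6-fold lower number from compound 2 to compound 3 (0.20 log units; within the scatter). An open chain with an ether oxygen and an aromatic ring with a nitrogen can therefore occupy this saturated chain carbon, and compound 2 and compound 3 still cannot be told apart in how much compound the cells tolerate. Compound 1 offers no number to set against this result, and it differs from the others in more than one place, so its value stands only as a limit: the limit of > 25000 nM in this assay, at which 1 of the 3 values shown sits.

This single pair cannot show whether the same holds for other groups at this carbon, such as an amine, a carboxylic acid or a longer chain. It also leaves open whether a different aromatic ring, such as phenyl, would give a step beyond the scatter.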